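Adding a chloro to the ring of compound 3

The source may hold more compounds than are shown below. What is called first, only, known or untested is meant among the compounds shown, and "the series" means these compounds.

Compound 1 `CC[C@H]1c2c(cc(F)c(F)c2O)[C@H](Nc2cccc3[nH]c(=O)ccc23)[C@@](O)(C(F)(F)F)C1OC` gives 3.1
Compound 2 `CCSC[C@@](O)([C@@H](Nc1cccc2nc(C)ccc12)c1ccc(C)cc1)C(F)(F)F` gives 4.8
Compound 3 `CCSC[C@@](O)([C@@H](Nc1cccc2nc(C)ccc12)c1cccc(F)c1OC)C(F)(F)F` gives 4.6

In a physicochemical assay for lipophilicity (a higher number here means a more lipophilic compound, a lower number a more polar compound), compound 3 stands at 4.6 and lies level with compound 2 within the scatter, while compound 1 lies lower by a gap beyond the scatter. The next compound, compound 4 `CCSC[C@@](O)([C@@H](Nc1cccc2nc(C)ccc12)c1ccc(Cl)c(F)c1OC)C(F)(F)F`, carries chloro in place of hydrogen on an aromatic carbon and so turns 3-fluoro-2-methoxyphenyl into 4-chloro-3-fluoro-2-methoxyphenyl. Among the compounds with values here, the one measured step that bears on this is a number 0.20 log units lower from compound 2 to compound 3 (within the scatter) and it exchanges 4-methylphenyl for 3-fluoro-2-methoxyphenyl. Within the data shown here, no measured step adds a chloro, so that step is only a loose guide and the data offer no direct measure of this change. Since a chlorine enters and only a hydrogen leaves, a modest upward move is expected, estimated as a number 0.50 log units higher from compound 3 to compound 4 (beyond the scatter) on the same scale. For compound 4 the expected value is 5.1 and the estimated range runs from 4.7 to 5.5 on that scale.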

Compound 4, partition coefficient: 5.3
Compound 4: middle estimate off by 0.20 log units, on the low side; the measured number falls inside the stated range.
By their numbers in this assay, from the lowest: compound 1; then compounds 3 and 2 (each within the scatter of the next); then compound 4.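

In this assay, chloro in place of hydrogen on an aromatic carbon, ortho to a fluoro group and meta to a methoxy group, gives a number 0.70 log units higher from compound 3 to compound 4 (beyond the scatter), the first measured effect of adding a chloro at this position. The earlier exchange, a number 0.20 log units lower from compound 2 to compound 3 (within the scatter), left those two ring patterns level within the scatter, whereas the chlorinated ring separates from 4-methylphenyl, with a number 0.50 log units higher from compound 2 to compound 4 (beyond the scatter). Nothing in the data accounts for the rise.

As far as these compounds go, what a bromo, a nitrile or an amine would do on this aromatic carbon remains open, as does the effect of the same chloro on another aromatic carbon of the ring. Also open, from the compounds shown here alone, is whether the chloro step would keep its size with a carboxylic acid in place of the ethylthio group.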